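From 3-Hydroxyphenyl to 4-Hydroxyphenyl in Oral Exposure

A few compounds are considered here, and "the series" means these few. Any claim that something is new, unique, unknown or untested is made for them only; others in the source may bear on it.

In an ADME assay on the whole organism for pharmacokinetics, with Mus musculus as the target, at a dose of 10 mg/kg by the oral route (on this read-out lower numbers stand for lower exposure and higher numbers for higher exposure at the dose given), compound 2 `CC1=C(c2cccc(O)c2)C(c2ccc(OC[C@H](C)N3CC[C@@H](C)C3)cc2)Oc2cc(O)ccc21` gives 50 ng.h/mL, the lowest of three numbers, against compound 3 `CC1=C(c2ccc(O)cc2)C(c2ccc(OC[C@H](C)N3CC[C@@H](C)C3)cc2)Oc2ccc(O)cc21` at 460 ng.h/mL and compound 1 `CC1=C(c2ccccc2)C(c2ccc(OC[C@H](C)N3CC[C@@H](C)C3)cc2)Oc2ccc(O)cc21` at 1000 ng.h/mL. Compound 4 `CC1=C(c2ccc(O)cc2)C(c2ccc(OC[C@H](C)N3CC[C@@H](C)C3)cc2)Oc2cc(O)ccc21` has the same atoms as compound 2, joined differently: 4-hydroxyphenyl in place of 3-hydroxyphenyl on a double-bonded ring carbon. Among the measured compounds shown here, no measured step makes this exchange. The closest evidence is a 2.2-fold lower number from compound 1 to compound 3 (0.34 log units; beyond the scatter), a modest step in which hydroxy replaces hydrogen on an aromatic carbon. It shows that a 4-hydroxyphenyl group is compatible with the number of compound 3 at 460 ng.h/mL, so a rise is expected. The estimated change is a 3.0-fold higher number from compound 2 to compound 4 (0.48 log units; beyond the scatter). Compound 4 is expected at 150 ng.h/mL, with an estimated range of 50 ng.h/mL to 450 ng.h/mL.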

Compound 4, area under the concentration-time curve: 120 ng.h/mL
Compound 4: middle estimate off by 1.3-fold (0.10 log units), on the high side; measured number inside the range.
By their numbers in this assay, from the lowest: compound 2; then compound 4; then compound 3; then compound 1.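

In this assay, 4-hydroxyphenyl in place of 3-hydroxyphenyl on a double-bonded ring carbon gives a 2.4-fold higher number from compound 2 to compound 4 (0.38 log units; beyond the scatter). Among the compounds shown here, since the two compounds have the same atoms, joined differently, this step shows that the place of the hydroxy on this phenyl ring alone changes the number, which no earlier step could show. Nothing at hand explains the rise. The compounds shown leave open how a methoxy group, a fluorine or an amine in place of this hydroxy would read at the same position.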